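Swapping a Methyl for a Halogenated Benzyl

This account rests on a few compounds, and the source may have more. Where it says the series, first, only, none or still open, it means among the compounds named here.

Going by the values given here, compound 1 `CCCn1c(=O)[nH]c2nc(-c3ccc(S(=O)(=O)N4CCN(C)CC4)cc3)[nH]c2c1=O` gives 48.2 nM in an assay on CHO cells for displacement of a labelled ligand from adenosine receptor A2b (Homo sapiens), read by scintillation counting, with a stated time of 75 min, in the presence of a further agent that is not named here (a lower number here means a stronger inhibitor, a higher number a weaker inhibitor), the highest of the two numbers so far; its nearest neighbour, compound 2 `CCCn1c(=O)c2[nH]c(-c3ccc(S(=O)(=O)N4CCN(c5ccc(Cl)cc5)CC4)cc3)nc2n(CC)c1=O`, gives 4.31 nM, a gap that lies beyond the scatter. Compound 3 `CCCn1c(=O)[nH]c2nc(-c3ccc(S(=O)(=O)N4CCN(Cc5ccc(Br)c(F)c5)CC4)cc3)[nH]c2c1=O` has not yet been measured. It differs from compound 1 by 4-bromo-3-fluorophenyl in place of hydrogen on a saturated chain carbon bound to an amine nitrogen in a ring. Among the compounds with values here, no measured pair shows this change on its own, so the expectation rests only on the two values shown. Compound 3 is expected to give 12 nM, within 4 nM to 40 nM, an estimated step of a 4.0-fold lower number from compound 1 to compound 3 (0.60 log units; beyond the scatter) towards stronger inhibition.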

Compound 3, inhibition constant: 0.473 nM
For compound 3 the middle estimate is 25-fold (1.40 log units) above the measured one; the whole stated range lies above it.
By their numbers in this assay, from the lowest: compound 3; then compound 2; then compound 1.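

In this assay, going from methyl to 4-bromo-3-fluorobenzyl gives a 100-fold lower number from compound 1 to compound 3 (2.01 log units; beyond the scatter), a large step towards stronger inhibition. This place on the amine nitrogen in a ring therefore accepts a far bigger group than methyl, and here the added halogenated aromatic ring goes with a gain rather than a loss. Nothing shown gives a measured reason for this gain. As far as these compounds go, how a plain benzyl group would compare at this place remains open, so the share of the gain tied to the bromine and the fluorine cannot yet be told.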